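Removing one 4-cyanophenyl arm from the triazole-bearing carbon

The source may hold more compounds than are shown below. What is called first, only, known or untested is meant among the compounds shown, and "the series" means these compounds.

Of the compounds shown here, three sharing one core have been measured in an assay on isolated protein for inhibition of Aromatase (Homo sapiens), read by fluorescence and colorimetric assay, with a stated time of 30 min; a higher number here means a weaker inhibitor, a lower number a stronger inhibitor. Compound 1 `N#Cc1ccc(OCc2cn(C(c3ccc(C#N)cc3)c3ccc(C#N)cc3)nn2)cc1` gives 4640 nM and stands lowest of the three numbers. Compound 2 `Cc1ccc(OCc2cn(C(c3ccc(C#N)cc3)c3ccc(C#N)cc3)nn2)cc1` gives 11000 nM, and compound 3 `COc1ccc(OCc2cn(C(c3ccc(C#N)cc3)c3ccc(C#N)cc3)nn2)cc1` gives 12200 nM. The steps of a 2.4-fold higher number from compound 1 to compound 2 (0.37 log units; beyond the scatter) and a 2.6-fold higher number from compound 1 to compound 3 (0.42 log units; beyond the scatter) both come from exchanging the nitrile on the aryl ether for methyl or methoxy, while a 1.1-fold higher number from compound 2 to compound 3 (0.04 log units; within the scatter) is within the scatter.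

Compound 4 `N#Cc1ccc(Cn2cc(COc3ccc(C#N)cc3)nn2)cc1` differs from compound 1 in another place: hydrogen in place of 4-cyanophenyl on a saturated chain carbon bound to an aromatic carbon and an aromatic nitrogen. For the measured compounds named here, none of the measured steps touches this carbon; all of them vary the aryl ether, so they tell nothing directly about losing a whole 4-cyanophenyl group here. What they do show is that every change made so far to compound 1 has weakened inhibition, and the removal of a group of this size is a larger change than any of those. The step of a 3.9-fold higher number from compound 1 to compound 4 (0.59 log units; beyond the scatter) is therefore expected to run toward a higher number, and with wide uncertainty. Compound 4 is estimated at 18000 nM, in a range from 4500 nM to 70000 nM.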

Compound 4, half-maximal inhibitory concentration: 9160 nM
Compound 4: the middle estimate sits 2.0-fold (0.29 log units) above what was measured; the measured number falls inside the stated range.
By their numbers in this assay, from the lowest: compounds 1, 4, 2 and 3 (each within the scatter of the next, the first and the last beyond it).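

For the compounds shown here, the first change at the saturated chain carbon bound to an aromatic carbon and an aromatic nitrogen shows that, in this assay, replacing a whole 4-cyanophenyl group with hydrogen leaves the number within the scatter (a 2.0-fold higher number from compound 1 to compound 4 (0.30 log units; within the scatter)). Losing 8 heavy atoms, one of the aromatic rings and one nitrile at this carbon therefore has no effect that this assay can separate from the scatter, whereas the smaller exchanges of the nitrile on the aryl ether went beyond it. No supporting evidence bears on this result, so it remains an observation without an explanation.

The compounds shown leave open whether a methyl, a phenyl without its nitrile or an amine on this carbon would fit the same picture. They also leave open whether methyl or methoxy in place of the aryl ether nitrile would have the same effect on the core of compound 4.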